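The source may hold more compounds than are shown below. What is called first, only, known or untested is meant among the compounds shown, and "the series" means these compounds.

Compounds measured so far:
- Compound 1 `Ic1ccc(Cn2cc(CCCOc3cccc4cccnc34)nn2)cc1` — in a functional assay on U-251 cells (Homo sapiens) for inhibition, read by sulforhodamine B assay, with a stated time of 48 h (on this read-out higher numbers stand for weaker inhibition of growth and lower numbers for stronger inhibition of growth), compound 1 gives only a limit, > 250 ug/mL.
- Compound 2 `Fc1ccc(Cn2cc(CCCOc3cccc4cccnc34)nn2)cc1` — in this assay compound 2 gives 20.7 ug/mL.

Among the measured compounds shown here, compound 2 holds the only actual number in this assay; the other value shown is a limit (the limit of > 250 ug/mL in this assay, at which 1 of the 2 values shown sits). For the measured compounds named here, the single measured step, an at least 12-fold lower number from compound 1 to compound 2 (1.08 log units; beyond the scatter), is large and lies beyond the scatter.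

Compound 3 `Clc1ccc(Cn2cc(CCCOc3cccc4cccnc34)nn2)cc1` differs from compound 2 by chloro in place of fluoro on an aromatic carbon, on an aromatic carbon of a six-membered aromatic ring of carbon only, para to a large group. Going by the values given here, the one step that bears on this change, an at least 12-fold lower number from compound 1 to compound 2 (1.08 log units; beyond the scatter), runs from iodo to fluoro; chloro stands between those two halogens, so a step in the weaker direction is expected, though of uncertain size. Compound 3 is therefore estimated at 50 ug/mL, with a range from 15 ug/mL to 250 ug/mL, which amounts to an expected step of a 2.4-fold higher number from compound 2 to compound 3 (0.38 log units; beyond the scatter).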

Compound 3, concentration for 50% growth inhibition: 3.4 ug/mL
Beside the measured number, compound 3's estimate is 15-fold (1.17 log units) above it; measured number below the stated range.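

In this assay, the three halogens at this place, on an aromatic carbon of a six-membered aromatic ring of carbon only, para to a large group, do not line up in the order of the halogens: chloro, not fluoro, gives the lowest number. Exchanging fluoro for chloro, one heavy atom for another, brings a 6.1-fold lower number from compound 2 to compound 3 (0.78 log units; beyond the scatter), and exchanging iodo for chloro brings an at least 73-fold lower number from compound 1 to compound 3 (1.86 log units; beyond the scatter). Compound 1 gives only a limit, so the second step marks a bound and not a size: the limit of > 250 ug/mL in this assay, at which 1 of the 3 values shown sits.

From the compounds shown here alone, what bromo, a methyl group or a methoxy group would give at this place remains open, and so does whether chloro keeps its lead over fluoro with a longer chain on the shared core. The compounds shown also do not tell why chloro stands apart from the other two halogens.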